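Thiazine amidines: acetyl on the aniline ring of compound 1

The source may report more compounds than this note shows. Statements on the series, on what has been measured and on what is new or still open speak of the compounds shown alone.

Measured so far:
compound 1 `c1ccc(NC2=NCCC3(CCCCC3)S2)cc1` — 63100 nM
compound 2 `CCc1cccc(CC)c1NC1=NCCC2(CCCCC2)S1` — 7900 nM
compound 3 `Cc1cc(C)c(NC2=NCCC3(CCCCC3)S2)c(C)c1` — 9300 nM

In a functional assay on a subcellular fraction from brain (Rattus norvegicus) for inhibition, read by scintillation counting, with a stated time of 5 min (a lower number here means a stronger inhibitor, a higher number a weaker inhibitor), compound 1 gives 63100 nM, the highest of the three numbers. Compound 2 gives 7900 nM and compound 3 gives 9300 nM; both lie lower than compound 1, each beyond the scatter, so compound 1 is the weakest inhibitor of the three. Compounds 2 and 3 carry alkyl groups on the aniline ring; the unsubstituted ring of compound 1 stands alone.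

Compound 4 `CC(=O)c1ccc(NC2=NCCC3(CCCCC3)S2)cc1` differs from compound 1 in one place: acetyl in place of hydrogen on an aromatic carbon. Among the compounds with values here, no pair among the measured compounds shows this kind of change, and the alkyl substitution seen in compounds 2 and 3 is of a different kind, so no measured step can be carried over. The expectation is therefore that the step from compound 1 to compound 4, a 1.0-fold lower number from compound 1 to compound 4 (0.00 log units; within the scatter), stays within the usual scatter, with no direction that can be called. On that basis compound 4 is estimated at 63000 nM in this assay, with a range from 18000 nM to 220000 nM. The number for compound 4 settles this.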

Compound 4, half-maximal inhibitory concentration: 81300 nM
Compound 4: middle estimate off by 1.3-fold (0.11 log units), on the low side; the measured number falls inside the stated range.
By their numbers in this assay, from the lowest: compounds 2 and 3 (each within the scatter of the next); then compounds 1 and 4 (each within the scatter of the next).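

In this assay, acetyl in place of hydrogen on an aromatic carbon, para to a large group, gives a change that lies within the scatter (a 1.3-fold higher number from compound 1 to compound 4 (0.11 log units; within the scatter)), so this single change does not separate the two compounds. Within the data shown here, this is the only step that differs in one place, and thus the first direct reading of any substitution on this ring with the rest of the structure held constant. It shows that a group of this size, carrying a carbonyl, can stand at this position without a number that can be told apart from that of the ring bearing hydrogen there. Nothing measured here bears on why the step is this small.

An amine, a carboxylic acid or a longer chain at this same position could still move the number beyond the scatter, and a single acetyl step cannot speak for them. Also open, from the compounds shown here alone, is whether acetyl on another carbon of the ring, or on the alkyl-bearing rings of compound 2 and compound 3, would stay within the scatter as it does here.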